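A few compounds are considered here, and "the series" means these few. Any claim that something is new, unique, unknown or untested is made for them only; others in the source may bear on it.

In a functional assay on K562 cells (Homo sapiens) for inhibition, read by trypan blue exclusion, with a stated time of 72 h (a higher number here means a weaker inhibitor, a lower number a stronger inhibitor), three compounds sharing one core have been measured. Compound 1 `Cn1c(=O)c(S(=O)(=O)Cc2ccc(F)cc2F)cc2cnc(Nc3ccc4[nH]ccc4c3)nc21`, with 2,4-difluorobenzyl on the sulfonyl sulfur, gives 1000 nM. Compound 2 `Cn1c(=O)c(S(=O)(=O)c2ccc(F)cc2)cc2cnc(Nc3ccc4[nH]ccc4c3)nc21`, with 4-fluorophenyl there, gives 200 nM. Compound 3 `Cn1c(=O)c(S(=O)(=O)Nc2ccc(F)cc2)cc2cnc(Nc3ccc4[nH]ccc4c3)nc21`, with (4-fluorophenyl)amino, gives 5000 nM, the weakest of the three. Compound 4 `Cn1c(=O)c(S(=O)(=O)c2ccc([N+](=O)[O-])cc2F)cc2cnc(Nc3ccc4[nH]ccc4c3)nc21` carries 2-fluoro-4-nitrophenyl in place of (4-fluorophenyl)amino on the sulfonyl sulfur (2-fluoro-4-nitrophenyl in place of (4-fluorophenyl)amino on a sulfonyl sulfur). Its phenyl ring sits on sulfur as in compound 2, so the closest guide is the large 25-fold higher number from compound 2 to compound 3 (1.40 log units; beyond the scatter), read in reverse. The a 5.0-fold higher number from compound 1 to compound 3 (0.70 log units; beyond the scatter) is smaller. For the measured compounds named here, no measured compound carries a nitro group, so some of that gain may not carry over. A large drop is expected, a 17-fold lower number from compound 3 to compound 4 (1.22 log units; beyond the scatter). Compound 4 is estimated at 300 nM, within a range of 80 nM to 1200 nM.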

Compound 4, half-maximal inhibitory concentration: 200 nM
Beside the measured number, compound 4's estimate is 1.5-fold (0.18 log units) above it; low and high end bracket the measured number.
By their numbers in this assay, from the lowest: compounds 2 and 4 (each within the scatter of the next); then compound 1; then compound 3.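

In this assay there is no change at the digits printed from compound 2 to compound 4 (within the scatter), so adding the nitro group and a second fluorine to the phenyl ring on the sulfonyl sulfur leaves the number in place. With a 25-fold lower number from compound 3 to compound 4 (1.40 log units; beyond the scatter) and a 5.0-fold lower number from compound 1 to compound 4 (0.70 log units; beyond the scatter), a phenyl ring directly on sulfur now gives the lowest numbers in two compounds, with none going against this. No evidence is available to explain these steps. Going by these compounds, what remains open is whether the nitro group or the added fluorine alone would give the same number, and whether an amine or a carboxylic acid could stand in place of the nitro group.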